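Butyl in Place of Hydrogen on an Aromatic Nitrogen

The source may report more compounds than this note shows. Statements on the series, on what has been measured and on what is new or still open speak of the compounds shown alone.

Compound 1: `Cc1c(C(=O)Nc2ccc(Oc3ncnc4[nH]cc(-c5ccccc5)c34)c(F)c2)c(=O)c2cc(Cl)ccc2n1C` gives 1890 nM in an assay on isolated protein for inhibition of tyrosine-protein kinase receptor UFO (Homo sapiens), read by FRET and Z'-LYTE, with a stated time of 1.5 h; on this read-out higher numbers stand for weaker inhibition and lower numbers for stronger inhibition
Compound 2: `Cc1ccc2[nH]c(C)c(C(=O)Nc3ccc(Oc4ncnc5[nH]cc(-c6ccccc6)c45)c(F)c3)c(=O)c2c1` gives 560 nM in this assay

Of the two measured compounds, compound 2 gives the lowest number in this assay. Its nearest neighbour is compound 1, whose number lies above it by a gap beyond the usual scatter. Among the measured compounds shown here, compound 1 and compound 2 differ from each other in more than one place, so no single step between them can be isolated from these two values.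

Compound 3, `CCCCn1c(C)c(C(=O)Nc2ccc(Oc3ncnc4[nH]cc(-c5ccccc5)c34)c(F)c2)c(=O)c2cc(C)ccc21`, has not yet been measured in this assay. It differs from compound 2 by butyl in place of hydrogen on an aromatic nitrogen. The measured pair offers no isolated change of this kind, so the data give no firm direction for the step. Compound 3 is therefore expected to give 1000 nM, within a range of 300 nM to 4000 nM. That estimate implies a weakening of a 1.8-fold higher number from compound 2 to compound 3 (0.25 log units; within the scatter), a step that may or may not clear the scatter.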

Compound 3, half-maximal inhibitory concentration: 480 nM
The estimate for compound 3 lay 2.1-fold (0.32 log units) above the measured number, within the range that was stated.
By their numbers in this assay, from the lowest: compounds 3 and 2 (each within the scatter of the next); then compound 1.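

Among the compounds shown here, compound 2 and compound 3 give the first single change that can be read at this aromatic nitrogen: in this assay, butyl in place of hydrogen gives a 1.2-fold lower number from compound 2 to compound 3 (0.07 log units; within the scatter). Within this pair, then, the hydrogen on the nitrogen is not needed to hold the number, and a butyl chain there leaves the two compounds indistinguishable. This holds for one chain on one core, and the compounds shown offer no measurement that explains the outcome.

From the compounds shown here alone, it remains open whether the same position would accept a longer chain such as hexyl, a benzyl group, or a butyl chain ending in an amine or a carboxylic acid. It is also unknown whether any such group would take the number beyond the scatter in either direction.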